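The source may hold more compounds than are shown below. What is called first, only, known or untested is meant among the compounds shown, and "the series" means these compounds.

In an assay on isolated protein for inhibition of 2-Hydroxyacid oxidase 2 (Homo sapiens), tested at 10 uM (a lower number here means a weaker effect, a higher number a stronger effect of the compound at the concentration tested), compound 1 `Cc1n[nH]c(C(=O)O)c1Cc1cccc(-c2ccc(C#N)cc2)c1` gives 46%, while compound 2 `Cc1n[nH]c(C(=O)O)c1Cc1cccc(-c2ccccc2F)c1` gives 22%, the lower of the two numbers. Among the measured compounds shown here, the single measured step, a number 24 percentage points lower from compound 1 to compound 2 (beyond the scatter), shows that exchanging the group on this aromatic carbon can shift the read-out by a modest amount. Compound 3 `Cc1n[nH]c(C(=O)O)c1Cc1cccc(C(N)=O)c1` differs from compound 2 by carbamoyl in place of 2-fluorophenyl on an aromatic carbon. For the measured compounds named here, no measured step covers a carbamoyl at this place, so the direction remains open and the expectation is wide. Compound 3 is estimated to give 20%, between 0% and 50%. This estimate means an expected step of a number 2 percentage points lower from compound 2 to compound 3 (within the scatter).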

Compound 3, a percentage reported as inhibition, at one concentration (the size of the read-out at that concentration, not a potency): 8%
Beside the measured number, compound 3's estimate is 12 percentage points above it; measured number inside the range.
By their numbers in this assay, from the lowest: compound 3; then compound 2; then compound 1.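

In this assay, among the compounds shown here, carbamoyl, a group with no ring, gives the lowest number so far at this place on the aromatic carbon, with a number 14 percentage points lower from compound 2 to compound 3 (beyond the scatter) and a number 38 percentage points lower from compound 1 to compound 3 (beyond the scatter) as the two steps. Both groups carrying a six-membered aromatic ring therefore stand above carbamoyl here, although they also differ from each other. Nothing available explains this drop.
Open, as far as these compounds go, is whether the drop follows the loss of the ring or the carbamoyl itself. An amine, a carboxylic acid or a plain phenyl at this place would help separate the two.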